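A Smaller Sulfur-Bearing Group Replaces the Thienyl Ketone

A few compounds are considered here, and "the series" means these few. Any claim that something is new, unique, unknown or untested is made for them only; others in the source may bear on it.

Compound 1 `CC1(C)C=C(n2ccccc2=O)c2cc(C(=O)c3cccs3)ccc2O1` stands highest of the two compounds measured in a functional assay (aorta) with Rattus norvegicus as the target; on this read-out lower numbers stand for lower potency and higher numbers for higher potency (the scale is a negative logarithm); in this assay compound 1 gives 6.4. Compound 2 `CC1(C)C=C(n2ccccc2=O)c2cc(OCC(=O)c3ccc(F)cc3)ccc2O1` gives 4.63 in this assay, a number that lies beyond the scatter below compound 1. Compound 3 `CC1(C)C=C(n2ccccc2=O)c2cc(C(=N)S)ccc2O1` is not yet measured. It differs from compound 1 in one place: a group of 3 heavy atoms (1 carbon, 1 nitrogen, 1 sulfur; no ring) in place of a group of 7 heavy atoms (5 carbon, 1 oxygen, 1 sulfur; one five-membered aromatic ring with 1 hetero atom), on an aromatic carbon. Among the compounds with values here, no measured pair shows a step of this kind. The step is expected to be a drop of moderate size, beyond the scatter, a number 0.90 log units lower from compound 1 to compound 3 (beyond the scatter). Compound 3 is therefore estimated at 5.5, with a range from 4.5 to 6.5.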

Compound 3, logarithm of the reciprocal of the active concentration, log(1/C): 6.21
Compound 3: middle estimate off by 0.71 log units, on the low side; the measured number falls inside the stated range.
By their numbers in this assay, from the lowest: compound 2; then compounds 3 and 1 (each within the scatter of the next).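

In this assay, the step from the (thiophen-2-yl)carbonyl to the much smaller group with no ring is a number 0.19 log units lower from compound 1 to compound 3 (within the scatter), so on this aromatic carbon the five-membered aromatic ring and its carbonyl are not required to keep the number. The entering group also brings hydrogen-bond donors that the leaving group lacks, yet the two compounds stand within the scatter of each other. The compounds shown leave open whether an amine or a carboxylic acid on this carbon would hold the number equally well, and whether the sulfur matters, since an oxygen-bearing counterpart such as a primary amide is not among them. Nothing at hand explains why these two groups read alike.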